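The compounds below may be only part of what the source reports. "The series", "measured", "known", "first", "only" and "open" are said of these compounds alone.

In a functional assay on DU-145 cells (Homo sapiens) for inhibition, read by trypan blue exclusion, with a stated time of 96 h (on this read-out higher numbers stand for weaker inhibition of growth and lower numbers for stronger inhibition of growth), compound 3 (`O=C(/C(=C\c1c(O)cc(O)cc1O)S(=O)(=O)c1ccccc1Br)c1ccc(Cl)cc1`) gives 50000 nM, level with compound 1 (`O=C(/C(=C\c1c(O)cc(O)cc1O)S(=O)(=O)c1ccccc1Br)c1ccc(Br)cc1`) at 50000 nM, the two highest of the three numbers, whereas compound 2 (`O=C(/C(=C\c1ccc([N+](=O)[O-])c(O)c1)SCc1ccc(Br)cc1)c1ccc(C(F)(F)F)cc1`) gives a lower 1000 nM. Compound 4 (`O=C(/C(=C\c1c(O)cc(O)cc1O)Sc1ccccc1Br)c1ccc(Cl)cc1`) has (2-bromophenyl)sulfanyl in place of (2-bromophenyl)sulfonyl on a double-bonded chain carbon bound to a carbonyl carbon and a double-bonded chain carbon. Among the compounds with values here, the only measured step, no change at the digits printed from compound 1 to compound 3 (within the scatter), is a chloro in place of bromo and gives no size for this change. Compound 2, with no sulfonyl group, at 1000 nM, differs in several other places, so it offers only weak support for a lower number. The expected change is a 5.0-fold lower number from compound 3 to compound 4 (0.70 log units; beyond the scatter). For compound 4 the estimate is 10000 nM, with an expected range of 1500 nM to 50000 nM.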

Compound 4, concentration for 50% growth inhibition: > 100000 nM
Compound 4: a limit, no number; the forecaster's own chance of this, stated with the estimate: 15%; middle value at least 10-fold (1.00 log units) away from the limit.
By their numbers in this assay, from the lowest: compound 2; then compounds 1 and 3 (each within the scatter of the next). At a limit, above all of these: compound 4.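

At this position, on a double-bonded chain carbon bound to a carbonyl carbon and a double-bonded chain carbon, (2-bromophenyl)sulfanyl in place of (2-bromophenyl)sulfonyl does not lower the number in this assay; the step reads an at least 2.0-fold higher number from compound 3 to compound 4 (0.30 log units; that floor lies within the scatter). Compound 4 gives > 100000 nM, which is a limit and not a number. The size of the step stays unfixed, and its floor does not clear the scatter: the limit of > 100000 nM in this assay, at which 1 of the 4 values shown sits.

Open: how a sulfinyl or an amine link at this carbon would read, and whether the sulfanyl swap behaves alike with the bromo of compound 1.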